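Working notes: aryl exchange on the benzylamine arm

The compounds below may be only part of what the source reports. "The series", "measured", "known", "first", "only" and "open" are said of these compounds alone.

Measured so far in a functional assay on CHOK cells for antagonist activity at growth hormone secretagogue receptor type 1 (Homo sapiens), read by calcium flux; a lower number here means a stronger inhibitor, a higher number a weaker inhibitor:
compound 1 `CCc1nc(N)nc(N)c1-c1ccc(NCc2cc(F)c(S(C)(=O)=O)c(F)c2)cc1`, 45 nM
compound 2 `CCc1nc(N)nc(N)c1-c1ccc(NCc2ccnc(Cl)c2)cc1`, 220 nM
compound 3 `Nc1nc(N)c(-c2ccc(NCc3ccnc(Cl)c3)cc2)c(COCc2ccccc2)n1`, 3.6 nM

Compound 3 gives the lowest number of the three in this assay; its nearest neighbour is compound 1 and its furthest is compound 2, both gaps beyond the scatter. Among the compounds with values here, the one step between compounds differing in a single place is a 61-fold lower number from compound 2 to compound 3 (1.79 log units; beyond the scatter), a change on the core substituent, not on the benzylamine arm.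

Compound 4 `COc1ccc(CNc2ccc(-c3c(N)nc(N)nc3COCc3ccccc3)cc2)cc1` is not yet measured. It differs from compound 3 by 4-methoxyphenyl in place of 2-chloropyridin-4-yl on a saturated chain carbon bound to a nitrogen on an aromatic ring. Within the data shown here, no measured pair differs in exactly this way. Compounds 1 and 2 carry different aryl groups on the same arm, on the ethyl core; compound 1 gives 45 nM and compound 2 gives 220 nM, so the identity of that aryl moves the number by a moderate amount, in a direction that cannot be tied to a methoxyphenyl group from these data.

For compound 4 a step of a 2.2-fold higher number from compound 3 to compound 4 (0.35 log units; beyond the scatter) is therefore expected, small and of uncertain direction. Compound 4 is estimated at 8 nM, with a range of 2 nM to 40 nM in this assay.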

Compound 4, half-maximal inhibitory concentration: 90 nM
Estimate against measurement, compound 4: 11-fold (1.05 log units) below; measured number above the stated range.
By their numbers in this assay, from the lowest: compound 3; then compounds 1 and 4 (each within the scatter of the next); then compound 2.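

In this assay, within the data shown here, the change from 2-chloropyridin-4-yl to 4-methoxyphenyl on a saturated chain carbon bound to a nitrogen on an aromatic ring gives a 25-fold higher number from compound 3 to compound 4 (1.40 log units; beyond the scatter) with the benzyloxy core substituent held constant, the only single-place reading at this position. Together with a 61-fold lower number from compound 2 to compound 3 (1.79 log units; beyond the scatter) on the core substituent, it shows that each of these two places can carry a large step on its own, and that the benzyloxy group does not by itself secure a number as low as that of compound 3. The data at hand offer no explanation for the size of the step at the aryl position.

Still open, as far as these compounds go, is which part of the exchange matters, since the two aryl groups differ at once in the ring nitrogen, the chlorine and the methoxy group, and a 4-chlorophenyl or an unsubstituted phenyl at this place would begin to separate these. Also open, from the compounds shown here alone, is whether a step of this size between the same two aryl groups would carry over to the core of compound 2.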